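Swapping the Pendant Heteroaryl for Thiophene

The source may hold more compounds than are shown below. What is called first, only, known or untested is meant among the compounds shown, and "the series" means these compounds.

The measured compounds and their values:
Compound 1 `c1cncc(-c2ccccc2OCC2=NCCN2)c1`: 109%
Compound 2 `Cc1cccc(-c2ccccc2OCC2=NCCN2)n1`: 80%
Compound 3 `c1ccc(-c2cnccn2)c(OCC2=NCCN2)c1`: 97%

In a functional assay with Alpha-1A adrenergic receptor (Homo sapiens) as the target, read by calcium flux (on this read-out lower numbers stand for smaller maximal responses and higher numbers for larger maximal responses), compound 3 stands second highest of the three numbers. Its nearest neighbour is compound 1, whose value is higher by a margin beyond the scatter, and furthest away is compound 2, whose value lies lower by a margin beyond the scatter. Going by the values given here, the one directly comparable step in this set is a number 12 percentage points lower from compound 1 to compound 3 (beyond the scatter), which puts pyrazin-2-yl in place of pyridin-3-yl on an aromatic carbon and gives a modest change beyond the scatter.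

Compound 4 `c1csc(-c2ccccc2OCC2=NCCN2)c1` differs from compound 3 only in this way: thiophen-2-yl in place of pyrazin-2-yl on an aromatic carbon

Among the compounds with values here, no measured step covers a five-membered ring entering at this place, so the expectation rests on the spread seen so far: the two changes of the pendant ring among compounds 1, 2 and 3 shifted the maximal response by modest amounts in either direction. Compound 4 is therefore expected to show a small change, a number 5 percentage points lower from compound 3 to compound 4 (within the scatter), most likely downward but close to the scatter. The estimate for compound 4 is 92%, with a range from 74% to 112%.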

Compound 4, largest response reached (reported as maximum), in percent of the reference or control that the assay uses: 101%
The estimate for compound 4 lay 9 percentage points below the measured number; low and high end bracket the measured number.
By their numbers in this assay, from the lowest: compound 2; then compounds 3, 4 and 1 (each within the scatter of the next, the first and the last beyond it).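

In this assay, the step to the five-membered ring reads a number 4 percentage points higher from compound 3 to compound 4 (within the scatter), and against the pyridine it reads a number 8 percentage points lower from compound 1 to compound 4 (within the scatter), so neither replacement moves the maximal response beyond the scatter. This shows that the pendant ring at this place, on an aromatic carbon ortho to a group of 7 heavy atoms, need not be six-membered or contain nitrogen for the response to stay within the scatter of both compound 1 and compound 3, even though those two compounds lie beyond the scatter of each other. Nothing available explains this tolerance.

From the compounds shown here alone, it remains open whether a furan-2-yl or thiazol-2-yl ring would fit the same picture, or whether a saturated ring such as piperidine would. Also open, going by these compounds, is whether a methyl group on the thiophene would lower the response, as compound 2 with its methyl-bearing pyridine might suggest.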